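The source may report more compounds than this note shows. Statements on the series, on what has been measured and on what is new or still open speak of the compounds shown alone.

In an assay for inhibition of mitogen-activated protein kinase kinase kinase 14 (Homo sapiens), read by luminescence and ADP-Glo, with a stated time of 120 min, in the presence of a further agent that is not named here (on this read-out higher numbers stand for weaker inhibition and lower numbers for stronger inhibition), compound 1 `CC(O)(C#Cc1cccc(Nc2ncnc3[nH]ccc23)c1)c1nccs1` gives 1640 nM, and compound 2 `CN(C)c1ccc(C#CC(C)(O)c2nccs2)cc1Nc1ncnc2[nH]ccc12` gives 22.5 nM. Among these two numbers compound 2 stands lowest; the only step measured so far is a 73-fold lower number from compound 1 to compound 2 (1.86 log units; beyond the scatter), a change on an aromatic carbon of the shared core.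

Compound 3 `CN(C)CCN(C)c1ccc(C#CC(C)(O)c2nccs2)cc1Nc1ncnc2[nH]ccc12` has not yet been measured. It differs from compound 2 in one place: (dimethylamino)methyl in place of hydrogen on a saturated chain carbon bound to a nitrogen on an aromatic ring. The change therefore builds out from the very group whose arrival produced the step of a 73-fold lower number from compound 1 to compound 2 (1.86 log units; beyond the scatter), but it does not repeat that step; the dimethylamino group is already present in both compound 2 and compound 3, and what enters is an extension of it. Within the data shown here, no measured step shows what such an extension does in this assay, so the size and direction of the step cannot be read from the numbers at hand. In this assay the step of a 1.3-fold higher number from compound 2 to compound 3 (0.12 log units; within the scatter) is expected to be modest, with the estimate for compound 3 set at 30 nM, within a range from 8 nM to 120 nM.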

Compound 3, half-maximal inhibitory concentration: 484 nM
Compound 3: middle estimate off by 16-fold (1.21 log units), on the low side; measured number outside the range, above it.
By their numbers in this assay, from the lowest: compound 2; then compound 3; then compound 1.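

In this assay, the result shows that the dimethylamino group does not tolerate every extension: adding (dimethylamino)methyl on its saturated chain carbon gives a 22-fold higher number from compound 2 to compound 3 (1.33 log units; beyond the scatter), which undoes much of the earlier gain of a 73-fold lower number from compound 1 to compound 2 (1.86 log units; beyond the scatter). The gain is not lost entirely, since the whole (2-(dimethylamino)ethyl)(methyl)amino group in place of hydrogen on the aromatic carbon still gives a 3.4-fold lower number from compound 1 to compound 3 (0.53 log units; beyond the scatter), so this larger group remains better on this read-out than hydrogen, though by a modest step rather than a large one. Nothing available explains why the extended group gives a number so much higher than dimethylamino does.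

With one extension in view, the chain and its end amine cannot be told apart as the source of the loss: a 2-methoxyethyl or a plain propyl group in place of the 2-(dimethylamino)ethyl group would separate them. From the compounds shown here alone, it also remains open whether a shorter addition, such as an ethyl group in place of one methyl on the nitrogen, would keep the low number of compound 2.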